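Azepane replaces the arylamino group on the shared core

This account rests on a few compounds, and the source may have more. Where it says the series, first, only, none or still open, it means among the compounds named here.

Two compounds of this series carry the same acylated aminomethyl arm on a trifluoromethyl-bearing core and differ only in the group next to the ring nitrogen. Compound 1 `CC(C(=O)NCc1ccc(C(F)(F)F)nc1NCC1CCN(C(=O)OC(C)(C)C)CC1)c1ccc(NS(C)(=O)=O)c(F)c1` gives in a functional assay on CHO-K1 cells for antagonist activity at transient receptor potential cation channel subfamily V member 1 (Homo sapiens), read by FLIPR (on this read-out lower numbers stand for stronger inhibition and higher numbers for weaker inhibition), a value of 1140 nM. Compound 2 `Cc1ccc(Nc2nc(C(F)(F)F)ccc2CNC(=O)C(C)c2ccc(NS(C)(=O)=O)c(F)c2)cc1C` gives in this assay a value of 1160 nM, the higher of the two numbers, though its distance to compound 1 lies within the scatter, so no order between them can be read. Compound 3 `CC(C(=O)NCc1ccc(C(F)(F)F)nc1N1CCCCCC1)c1ccc(NS(C)(=O)=O)c(F)c1` is not yet measured; it differs from compound 2 by azepan-1-yl in place of (3,4-dimethylphenyl)amino on an aromatic carbon. Among the measured compounds shown here, with only two near-identical values to build on, the step from compound 2 to compound 3 is expected to be small and of uncertain direction, a 1.3-fold higher number from compound 2 to compound 3 (0.11 log units; within the scatter), pointing if anything to a slightly higher number. Compound 3 is therefore expected to give in this assay about 1500 nM, within the range 500 nM to 5000 nM.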

Compound 3, half-maximal inhibitory concentration: 25.1 nM
Compound 3: the middle estimate sits 60-fold (1.78 log units) above what was measured, and the stated range ends above it.
By their numbers in this assay, from the lowest: compound 3; then compounds 1 and 2 (each within the scatter of the next).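

In this assay, azepan-1-yl in place of (3,4-dimethylphenyl)amino gives a 46-fold lower number from compound 2 to compound 3 (1.66 log units; beyond the scatter) and so shows that the group on this aromatic carbon, next to the ring nitrogen, can move the number far beyond the scatter, something the two level earlier values gave no sign of. The change removes an aromatic ring and a hydrogen-bond donor and brings in a seven-membered non-aromatic ring, and this single step cannot tell which of these differences counts. Nothing available explains the size of the step.

The compounds shown leave open whether a cyclohexylamino group, which keeps the donor on a non-aromatic ring, would stand nearer compound 2 or compound 3. They also leave open how a piperidin-1-yl or an open-chain diethylamino group would compare with azepan-1-yl at this place.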